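The source may hold more compounds than are shown below. What is called first, only, known or untested is meant among the compounds shown, and "the series" means these compounds.

Measured so far:
- compound 1, `O=C(Nc1cc(-c2ccccc2)nn1-c1ccccc1)c1cccc([N+](=O)[O-])c1`: 39 nM
- compound 2, `COc1ccc(C(=O)Nc2cc(-c3ccccc3)nn2-c2ccccc2)cc1`: 54 nM
- compound 3, `O=C(Nc1cc(-c2ccccc2)nn1-c1ccccc1)c1ccc(OC(F)(F)F)cc1`: 18 nM

In a functional assay on cells for positive allosteric modulation of metabotropic glutamate receptor 5 (Rattus norvegicus), read by calcium flux (a higher number here means that more compound is needed for the effect, a lower number that less compound is needed), compound 3 stands lowest of the three numbers, with compound 1 nearest and compound 2 furthest. Compound 4, `O=C(Nc1cc(-c2ccccc2)nn1-c1ccccc1)c1ccc([N+](=O)[O-])cc1`, arises from compound 3 by nitro in place of trifluoromethoxy on an aromatic carbon. Going by the values given here, two measured steps bear on this. The exchange a 1.4-fold higher number from compound 1 to compound 2 (0.14 log units; within the scatter) shows that a 3-nitrophenyl and a 4-methoxyphenyl give similar numbers, while a 3.0-fold lower number from compound 2 to compound 3 (0.48 log units; beyond the scatter) shows that trifluoromethoxy lowers the number against methoxy. Removing the trifluoromethoxy in favour of a nitro group is therefore expected to raise the number modestly, back toward that of compound 1. Compound 4 is estimated at 40 nM, range 15 nM to 110 nM, corresponding to an expected step of a 2.2-fold higher number from compound 3 to compound 4 (0.35 log units; beyond the scatter).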

Compound 4, half-maximal effective concentration: 10.7 nM
For compound 4 the middle estimate is 3.7-fold (0.57 log units) above the measured one, outside the stated range (below it).
By their numbers in this assay, from the lowest: compounds 4 and 3 (each within the scatter of the next); then compounds 1 and 2 (each within the scatter of the next).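

In this assay, nitro and trifluoromethoxy on this aromatic carbon, para to a large group, read alike, with a 1.7-fold lower number from compound 3 to compound 4 (0.23 log units; within the scatter), whereas nitro in place of methoxy gives a 5.0-fold lower number from compound 2 to compound 4 (0.70 log units; beyond the scatter). The place of the nitro also counts, as 4-nitrophenyl in place of 3-nitrophenyl gives a 3.6-fold lower number from compound 1 to compound 4 (0.56 log units; beyond the scatter). No measurement here accounts for these steps. The compounds shown leave open how an amine, a carboxylic acid or a longer chain would read at this same place on the shared core.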